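A Second Nitro Group, Tried on Another Core

The compounds below may be only part of what the source reports. "The series", "measured", "known", "first", "only" and "open" are said of these compounds alone.

Measured in a functional assay for inhibition, read by spectrophotometry, with a stated time of 120 min; on this read-out higher numbers stand for weaker inhibition and lower numbers for stronger inhibition:
compound 1 `CCOC(=O)N1CCC(=NNC(=O)c2ccc([N+](=O)[O-])cc2)CC1` gives 40200 nM
compound 2 `CCOC(=O)N1CCC(=NNC(=O)c2ccc([N+](=O)[O-])cc2[N+](=O)[O-])CC1` gives 27800 nM
compound 3 `O=C(NN=C1CC(c2ccccc2)NC(c2ccccc2)C1)c1ccc([N+](=O)[O-])cc1` gives 45200 nM

Compound 2 differs from compound 1 by nitro in place of hydrogen on an aromatic carbon, and this change made a 1.4-fold lower number from compound 1 to compound 2 (0.16 log units; within the scatter). Compound 4 `O=C(NN=C1CC(c2ccccc2)NC(c2ccccc2)C1)c1ccc([N+](=O)[O-])cc1[N+](=O)[O-]` differs from compound 3 by nitro in place of hydrogen on an aromatic carbon, the same change in the same surroundings. How the core of compound 3 differs from the core of compound 1 is not broken down here; in this assay the values of compound 1 and compound 3 lie within the scatter of each other. Since compound 3 and compound 1 give similar numbers, a step of similar size is expected, namely a 1.4-fold lower number from compound 3 to compound 4 (0.15 log units; within the scatter), resting on a 1.4-fold lower number from compound 1 to compound 2 (0.16 log units; within the scatter). For compound 4 the expected value in this assay is 32000 nM, estimated between 14000 nM and 75000 nM.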

Compound 4, half-maximal inhibitory concentration: 28200 nM
Compound 4: middle estimate off by 1.1-fold (0.05 log units), on the high side; the range from low to high includes it.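

In this assay the second nitro group gives a 1.6-fold lower number from compound 3 to compound 4 (0.20 log units; within the scatter), so this step is no larger than the differences expected between repeated measurements. Set beside the earlier step, the result on the two cores agrees: the same change on two cores in this assay, a 1.4-fold lower number (0.16 log units; within the scatter) from compound 1 to compound 2 and a 1.6-fold lower number (0.20 log units; within the scatter) from compound 3 to compound 4, 1.1-fold (0.04 log units) apart, within the scatter of two such steps. This shows that the change behaves alike on these two cores, but with both steps within the scatter, it does not show that the second nitro group alters inhibition on either core, and two cores cannot speak for the whole series.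

Going by these compounds, it remains open whether a different group on that aromatic carbon, such as an amine or a carboxylic acid, would give a step beyond the scatter. On these data alone, whether such a step would also carry from one core to the other is equally open.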